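Dropping Bromo for Hydrogen: From Compound 1 to Compound 3

The compounds below may be only part of what the source reports. "The series", "measured", "known", "first", "only" and "open" are said of these compounds alone.

compound 1 `O=C(N/N=C\c1cn(Cc2ccc(Cl)cc2)c2ccc(Br)cc12)c1c[nH]c2ccccc12` — 3600 nM
compound 2 `COc1ccc(Cn2cc(/C=N\NC(=O)c3cn(C)c4ccccc34)c3ccc(F)cc32)cc1` — 15200 nM

In a functional assay on DU-145 cells (Homo sapiens) for cytotoxicity (on this read-out lower numbers stand for stronger inhibition and higher numbers for weaker inhibition), compound 1 gives 3600 nM, the lowest of the two numbers. Compound 2 gives 15200 nM, a gap beyond the scatter. Compound 3 `O=C(N/N=C\c1cn(Cc2ccc(Cl)cc2)c2ccccc12)c1c[nH]c2ccccc12` differs from compound 1 in one place: hydrogen in place of bromo on an aromatic carbon. Within the data shown here, no measured pair shows this change on its own, so the size of the step is uncertain. A small loss of potency is expected, near the edge of the scatter. Compound 3 is expected to give 6500 nM with a range from 2500 nM to 16000 nM. This estimate means an expected step of a 1.8-fold higher number from compound 1 to compound 3 (0.26 log units; within the scatter).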

Compound 3, half-maximal inhibitory concentration: 52100 nM
Estimate against measurement, compound 3: 8.0-fold (0.90 log units) below, and the stated range ends below it.
By their numbers in this assay, from the lowest: compound 1; then compound 2; then compound 3.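

Replacing bromo with hydrogen on this aromatic carbon gives a 14-fold higher number from compound 1 to compound 3 (1.16 log units; beyond the scatter) in this assay. This is the only change in a single place among the compounds shown, and it reveals that the potency of compound 1 depends strongly on the group at this carbon, which compound 2 could not show. No measurement available here explains the size of this step.

Going by these compounds, it remains open whether a nitrile or an amine at this carbon would keep the potency of compound 1. On these data alone, it is also open whether the same step would appear with the other parts of compound 1 changed.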